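A few compounds are considered here, and "the series" means these few. Any claim that something is new, unique, unknown or untested is made for them only; others in the source may bear on it.

Measured in a functional assay on A549 cells (Homo sapiens) for antiproliferative activity, read by MTT assay, with a stated time of 72 h; on this read-out higher numbers stand for weaker inhibition and lower numbers for stronger inhibition: compound 1 `COc1cc2c(Oc3c(F)cc(NC(=O)NN4C(=O)CSC4c4c(F)cccc4F)cc3F)ccnc2cc1OCCCN1CCCC1` gives 560 nM; compound 2 `COc1cc2c(Oc3c(F)cc(NC(=S)NN4C(=O)CSC4c4c(F)cccc4F)cc3F)ccnc2cc1OCCCN1CCCC1` gives 690 nM; compound 3 `COc1cc2c(Oc3c(F)cc(NC(=O)NN4C(=O)CSC4c4c(F)cccc4F)cc3F)ccnc2cc1OCCCN1CCC(C)CC1` gives 970 nM.

Compound 3 sits at the upper end of these three numbers, but its gaps to the other two lie within the scatter: a 1.7-fold higher number from compound 1 to compound 3 (0.24 log units; within the scatter), and the numbers of compound 2 and compound 3 are closer still. Compound 4 `CCN(CC)CCCOc1cc2nccc(Oc3c(F)cc(NC(=O)NN4C(=O)CSC4c4c(F)cccc4F)cc3F)c2cc1OC` is not yet measured; it differs from compound 3 by diethylamino in place of 4-methylpiperidin-1-yl on a saturated chain carbon, three bonds along the chain from an oxygen on an aromatic ring. For the measured compounds named here, the only measured exchange at this place is the one from compound 1 to compound 3, which stayed within the scatter, so no step beyond the scatter is expected here either. For compound 4 in this assay the estimate is 750 nM (range 350 nM to 1600 nM), an expected step of a 1.3-fold lower number from compound 3 to compound 4 (0.11 log units; within the scatter).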

Compound 4, half-maximal inhibitory concentration: 450 nM
Beside the measured number, compound 4's estimate is 1.7-fold (0.22 log units) above it; measured number inside the range.
By their numbers in this assay, from the lowest: compounds 4, 1, 2 and 3 (each within the scatter of the next, the first and the last beyond it).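

In this assay this place gives its first step beyond the scatter (a 2.2-fold lower number from compound 3 to compound 4 (0.33 log units; beyond the scatter)), a modest one, so the exchange of 4-methylpiperidin-1-yl for diethylamino is not silent here. Against pyrrolidin-1-yl, diethylamino stays within the scatter (a 1.2-fold lower number from compound 1 to compound 4 (0.09 log units; within the scatter)), so among these compounds a ring on the chain is not needed to hold the number. No measurement at hand accounts for either step.

Open, from the compounds shown here alone, is how morpholin-4-yl, with a second hetero atom in the ring, would fare at this place. Also open, going by these compounds, is whether the shorter 2-(diethylamino)ethyl chain would hold the number.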